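This account rests on a few compounds, and the source may have more. Where it says the series, first, only, none or still open, it means among the compounds named here.

Measured compounds:
- compound 1 `CC(C)NC(=O)[C@H]1CC[C@@H](n2/c(=N/C(=O)c3ccc(C#N)c(F)c3)[nH]c3ccc(CN4CCC(C(C)(C)O)CC4)cc32)CC1`: 132 mL.min-1.g-1
- compound 2 `CC(C)NC(=O)[C@H]1CC[C@@H](n2/c(=N/C(=O)c3ccccc3)[nH]c3ccc(CN4CCC(C(C)(C)O)CC4)cc32)CC1`: 40 mL.min-1.g-1

Among the measured compounds shown here, in an in vitro ADME assay on microsomes from liver (Homo sapiens) for metabolic stability (a lower number here means slower removal, a higher number faster removal of the compound), compound 2 gives 40 mL.min-1.g-1, the lower of the two numbers so far, with compound 1 as its only neighbour at 132 mL.min-1.g-1; the step of a 3.3-fold lower number from compound 1 to compound 2 (0.52 log units; beyond the scatter) lies beyond the scatter and was modest. Compound 3 `CC(C)NC(=O)[C@H]1CC[C@@H](n2/c(=N/C(=O)c3ccncc3)[nH]c3ccc(CN4CCC(C(C)(C)O)CC4)cc32)CC1` is not yet measured; it differs from compound 2 in one place: pyridin-4-yl in place of phenyl on a carbonyl carbon. For the measured compounds named here, no measured step exchanges phenyl for pyridin-4-yl on this carbonyl carbon, so only the step of a 3.3-fold lower number from compound 1 to compound 2 (0.52 log units; beyond the scatter), which also altered the aryl group on that same carbonyl carbon, bears on it, and it bears only loosely. Compound 3 is therefore expected to stay close to compound 2 in this assay, with a step of a 1.3-fold lower number from compound 2 to compound 3 (0.12 log units; within the scatter) that is estimated to fall within the scatter. The estimate for compound 3 is 30 mL.min-1.g-1, in the range 12 mL.min-1.g-1 to 75 mL.min-1.g-1.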

Compound 3, intrinsic clearance in microsomes: 57 mL.min-1.g-1
Compound 3: middle estimate off by 1.9-fold (0.28 log units), on the low side; the range from low to high includes it.
By their numbers in this assay, from the lowest: compounds 2 and 3 (each within the scatter of the next); then compound 1.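

Placing pyridin-4-yl instead of phenyl on the carbonyl carbon, in this assay, gives a step that stays within the scatter (a 1.4-fold higher number from compound 2 to compound 3 (0.15 log units; within the scatter)), so exchanging this ring of carbon only for one with a ring nitrogen shows no readable change at this position. Compound 3 also stands apart from compound 1 (a 2.3-fold lower number from compound 1 to compound 3 (0.36 log units; beyond the scatter)), so compound 1, with its 4-cyano-3-fluorophenyl, is the one of the three set apart beyond the scatter, from both compound 2 and compound 3. No evidence on why these numbers fall as they do is available.

The compounds shown leave open whether 4-cyanophenyl or 3-fluorophenyl alone would account for the gap to compound 1, since the nitrile and the fluorine enter together. They also leave open whether pyridin-3-yl or pyridin-2-yl on this carbonyl carbon would stay with compound 2 and compound 3.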